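Hydroxyphenyl hydrazone in the HT-29 cytotoxicity series

The source may report more compounds than this note shows. Statements on the series, on what has been measured and on what is new or still open speak of the compounds shown alone.

Measured compounds:
compound 1 `COc1cc2c(Oc3ccc(NC(=O)N/N=C/c4ccc(C(F)(F)F)cc4)cc3F)ccnc2cc1OCCCN1CCCC1` 810 nM
compound 2 `COc1cc2c(Oc3ccc(NC(=O)N/N=C/c4ccc(F)cc4Cl)cc3F)ccnc2cc1OCCCN1CCCCC1` 260 nM
compound 3 `COc1cc2c(Oc3ccc(NC(=O)N/N=C/c4ccc(Cl)cc4Cl)cc3F)ccnc2cc1OCCCN1CCCCC1` 370 nM

Three hydrazone ureas built on a shared core have been measured in a functional assay on HT-29 cells (Homo sapiens) for cytotoxicity, read by MTT assay, with a stated time of 72 h; a higher number here means a weaker inhibitor, a lower number a stronger inhibitor. For the measured compounds named here, compound 3 `COc1cc2c(Oc3ccc(NC(=O)N/N=C/c4ccc(Cl)cc4Cl)cc3F)ccnc2cc1OCCCN1CCCCC1` stands second highest of the three numbers with 370 nM; its nearest neighbour is compound 2, whose value is 260 nM, and the step of a 1.4-fold higher number from compound 2 to compound 3 (0.15 log units; within the scatter) is the only single-point change among the measured compounds. Going by the values given here, compound 1 gives 810 nM, the highest of the three, but it differs from compound 3 in two places, so no single step connects them.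

Compound 4 `COc1cc2c(Oc3ccc(NC(=O)N/N=C/c4ccc(O)cc4)cc3F)ccnc2cc1OCCCN1CCCCC1` arises from compound 3 by the change (4-hydroxyphenyl in place of 2,4-dichlorophenyl on a carbon with a double bond to nitrogen). Among the compounds with values here, none of the measured steps covers a hydroxyl on that ring; the one step on hand, a 1.4-fold higher number from compound 2 to compound 3 (0.15 log units; within the scatter), swaps one halogen for another and stays within the scatter, and it says nothing about removing both halogens and adding a donor-acceptor group. The expectation therefore rests on little: compound 4 is estimated at 650 nM, with a range of 200 nM to 2500 nM, which means an expected step of a 1.8-fold higher number from compound 3 to compound 4 (0.24 log units; within the scatter) in this assay, leaning towards a higher number but with wide uncertainty.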

Compound 4, half-maximal inhibitory concentration: 470 nM
For compound 4 the middle estimate is 1.4-fold (0.14 log units) above the measured one; measured number inside the range.
By their numbers in this assay, from the lowest: compounds 2, 3, 4 and 1 (each within the scatter of the next, the first and the last beyond it).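

In this assay the 4-hydroxyphenyl on a carbon with a double bond to nitrogen gives a 1.3-fold higher number from compound 3 to compound 4 (0.10 log units; within the scatter) when it replaces 2,4-dichlorophenyl, and a 1.8-fold higher number from compound 2 to compound 4 (0.26 log units; within the scatter) when it replaces 2-chloro-4-fluorophenyl. Until now this position had been probed only by exchanging one halogen for another, whereas these two steps remove both halogens and raise the counts from 0 to 1 hydrogen-bond donor and from 0 to 1 hydrogen-bond acceptor, and neither step goes beyond the scatter in these three compounds. No independent evidence on the cause of this result is available.

Going by these compounds, a plain phenyl at this place would separate the loss of the halogens from the arrival of the hydroxyl, and it remains open whether a 4-methoxyphenyl, a 4-aminophenyl or a 4-carboxyphenyl would also stay within the scatter. On these data alone, compound 1 differs from compound 4 in two places, so the comparison between them cannot be read, and the effect of the 4-hydroxyphenyl on the core of compound 1 remains open as well.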